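This account rests on a few compounds, and the source may have more. Where it says the series, first, only, none or still open, it means among the compounds named here.

Of the compounds shown here, three built on one shared core have been measured in a functional assay on the whole organism (Ehrlich cells, Mus musculus) for antiproliferative activity, with a stated time of 24 h, at a dose of 0.2 mmol/kg by the intraperitoneal route; on this read-out higher numbers stand for more inhibition at the one dose given (going by the name of the read-out) and lower numbers for less inhibition. Compound 3, `COc1ccc(NC(=O)CNc2ccc(C(=O)Nc3ccccc3N)cc2)cc1`, gives 62.3%, the highest of the three. Compound 1, `Nc1ccccc1NC(=O)c1ccc(NCC(=O)Nc2cccc([N+](=O)[O-])c2)cc1`, gives 40.4%, and compound 2, `Cc1ccc(NC(=O)CNc2ccc(C(=O)Nc3ccccc3N)cc2)cc1`, gives 25.2%. Both steps leading to compound 3 lie beyond the scatter: a number 21.9 percentage points higher from compound 1 to compound 3 (beyond the scatter) and a number 37.1 percentage points higher from compound 2 to compound 3 (beyond the scatter). The step between the two compounds with the lower numbers, a number 15.2 percentage points lower from compound 1 to compound 2 (beyond the scatter), also lies beyond the scatter.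

Compound 4, `Nc1ccccc1NC(=O)c1ccc(NCC(=O)Nc2ccc(Cl)cc2)cc1`, has not yet been measured. It differs from compound 3 by chloro in place of methoxy on an aromatic carbon. Among the measured compounds shown here, no measured step exchanges methoxy for chloro, so the nearest guides are the two steps into compound 3. Both show a lower number where the ring carries methyl or nitro instead of methoxy. Chloro, like methyl, brings no hydrogen-bond acceptor, yet nitro, which carries acceptors, still gave less than methoxy, so acceptor count alone does not settle the matter. The expectation is a fall beyond the scatter, landing somewhere between the numbers of compound 1 and compound 2: a number 27.3 percentage points lower from compound 3 to compound 4 (beyond the scatter) is what is expected. Compound 4 is estimated at 35%, with a range from 15% to 58%.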

Compound 4, a percentage reported as inhibition, in the whole organism at one dose (the size of the read-out at that dose, not a potency): 73.3%
The estimate for compound 4 lay 38.3 percentage points below the measured number; the measured number lies above the stated range.
By their numbers in this assay, from the lowest: compound 2; then compound 1; then compound 3; then compound 4.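

At this position, on an aromatic carbon para to a large group, methoxy no longer gives the highest number in this assay, since chloro, which brings no hydrogen-bond acceptor, gives a number 11 percentage points higher from compound 3 to compound 4 (beyond the scatter) and shows that among these compounds the acceptor of methoxy is not needed for a high reading. Among the compounds shown here, the same position now spans the widest gap in the set, with a number 48.1 percentage points higher from compound 2 to compound 4 (beyond the scatter) for the single exchange of methyl for chloro, so a small change on this ring can move the reading a long way; the exchange of the whole ring group gives a number 32.9 percentage points higher from compound 1 to compound 4 (beyond the scatter), but there the substituent's place on the ring changes along with the group itself. Nothing available explains these differences.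

Going by these compounds, whether fluoro, bromo, or an amine or carboxylic acid at this position would read closer to chloro or to methyl stays open, as does how 3-chlorophenyl would compare with 4-chlorophenyl. Each reading also comes from a single dose, so these numbers leave open how the compounds would rank at other doses.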